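A few compounds are considered here, and "the series" means these few. Any claim that something is new, unique, unknown or untested is made for them only; others in the source may bear on it.

Measured in a toxicity assay on THP-1 cells (Homo sapiens) for inhibition; a higher number here means that more compound is tolerated, a lower number that less compound is tolerated:
- Compound 1 `COc1ccc(-c2cnc(NC(=O)c3ccccc3O)n2C)cc1`: > 100000 nM
- Compound 2 `COc1ccc(-c2cnc(NC(=O)c3cccc([N+](=O)[O-])c3)n2C)cc1`: > 100000 nM
- Compound 3 `COc1ccc(-c2cn(C)c(NC(=O)c3ccc(F)cc3)n2)cc1`: > 50000 nM

Compound 1 stands at > 100000 nM, which is a limit of the assay and not a number. Compound 2 gives > 100000 nM, also a limit. Compound 3 gives > 50000 nM, again a limit.

Compound 4 `COc1ccc(-c2cnc(NC(=O)c3cccnc3)n2C)cc1` keeps the core of compound 1 and changes one group: pyridin-3-yl in place of 2-hydroxyphenyl on a carbonyl carbon. In words, pyridin-3-yl takes the place of 2-hydroxyphenyl on a carbonyl carbon. Within the data shown here, no two measured compounds differ in one place only, so the data offer no measured step to use as a guide. With compound 1 at > 100000 nM, the expectation in this assay is a change no larger than the scatter. The estimated change is a number no higher from compound 1 to compound 4 (the limit leaves the size open). For compound 4 the expected value is 100000 nM, with an estimated range from 50000 nM to 200000 nM. The result for compound 4 may well be reported as a limit too.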

Compound 4, half-maximal cytotoxic concentration: > 100000 nM
Compound 4: only a limit was reported; the forecaster's own chance of this, stated with the estimate: 85%; the middle value sits exactly at the limit.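

In this assay, among these compounds, compound 1 and compound 4 are both reported only as limits of the assay and not as numbers, so no step between them can be read. The compounds shown leave open at what concentration any of them would harm these cells.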